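The compounds below may be only part of what the source reports. "The series", "measured", "known", "first", "only" and "open" are said of these compounds alone.

Values measured in a functional assay on MDA-MB-231 cells (Homo sapiens) for cytotoxicity, read by sulforhodamine B assay, with a stated time of 3 days; a higher number here means that more compound is needed for the effect, a lower number that less compound is needed:

- compound 1 `COc1c(-c2occ(C)c2C(=O)O)ccc2c1CCCC2(C)C`: > 61 uM
- compound 2 `CCc1cccc2c(O)c(-c3occ(C)c3C(=O)O)ccc12`: > 37 uM
- compound 3 `Cc1coc(-c2ccc3c(c2O)CCC3)c1C(=O)O`: 44.6 uM

Compound 1 stands at the limit of > 61 uM in this assay, at which 1 of the 3 values shown sits, which is a limit and not a number. Compound 2 is also reported only as a limit, at the limit of > 37 uM in this assay, at which 1 of the 3 values shown sits. Compound 3 alone gives a number, 44.6 uM. The two limits therefore leave the order of the three compounds open, and compound 1 cannot be placed exactly among them.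

The account now turns to compound 4 `COc1c(-c2occ(C)c2CO)ccc2c1CCCC2(C)C`, which keeps the core of compound 1 and has hydroxymethyl in place of carboxy on an aromatic carbon. Going by the values given here, all three measured compounds carry the carboxy group, so no measured pair shows what this exchange does in this assay. Among the compounds with values here, the expectation therefore leans on compound 3, which gives 44.6 uM, the only number available as an anchor. A moderate move towards less compound being needed is expected, though it may not clear the scatter by much, and a further limit remains quite possible. The estimated change is an at least 2.0-fold lower number from compound 1 to compound 4 (0.30 log units; that floor lies within the scatter). For compound 4 the expected value is 30 uM, with an estimated range of 10 uM to 70 uM.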

Compound 4, concentration for half-maximal effect: 28.3 uM
Estimate against measurement, compound 4: 1.1-fold (0.03 log units) above; low and high end bracket the measured number.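

Going by these compounds alone, compound 4 supplies the first pair in this assay that differs in one place: with the shared core unchanged, hydroxymethyl in place of carboxy on this aromatic carbon of the five-membered aromatic ring gives an at least 2.1-fold lower number from compound 1 to compound 4 (0.33 log units; beyond the scatter). The three earlier compounds all carry carboxy here, so they could not show what this exchange does, whereas compound 4, the only one of the four without carboxy, gives a true number of 28.3 uM. The step can be read only as a floor, and its real size remains unknown, because compound 1 is reported as a limit and not a number: the limit of > 61 uM in this assay, at which 1 of the 4 values shown sits.

The compounds shown leave open whether the same exchange would give a similar step on the different cores of compound 2 and compound 3, since neither core appears here with hydroxymethyl in this place. They also leave open whether the step follows from hydroxymethyl itself or simply from the absence of carboxy, and what a methyl ester, a primary amide or an aminomethyl group would give on the same aromatic carbon.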